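Removing one ester from a limonoid scaffold

This account rests on a few compounds, and the source may have more. Where it says the series, first, only, none or still open, it means among the compounds named here.

Three compounds sharing one core were tested in a functional assay on DU-145 cells (Homo sapiens) for inhibition, read by MTT assay, with a stated time of 24 h; on this read-out higher numbers stand for weaker inhibition and lower numbers for stronger inhibition. Compound 1 `C/C=C(\C)C(=O)O[C@H]1[C@]2(C)C[C@@H]3O[C@@]1(O)C=C1C4=CC(=O)O[C@@H](c5ccoc5)[C@]4(C)CC[C@@H]1[C@]3(C)[C@@H]2[C@@H](O)C(=O)OC` gives 7700 nM. Compound 2 `COC(=O)[C@H](O)[C@@H]1[C@@]2(C)C[C@@H]3O[C@@](O)(C=C4C5=CC(=O)O[C@@H](c6ccoc6)[C@]5(C)CC[C@@H]4[C@@]31C)[C@H]2O` reaches only a limit of the assay, > 100000 nM. Compound 3 `C/C=C(\C)C(=O)O[C@@H]1[C@]2(OC(=O)CCCC)C=C3C4=CC(=O)O[C@@H](c5ccoc5)[C@]4(C)CC[C@@H]3[C@@]3(C)[C@H](C[C@]1(C)[C@H]3[C@@H](OC(=O)CCCC)C(=O)OC)O2` gives 4200 nM, the lowest of the two numbers, though its gap to compound 1 lies within the scatter. Going by the values given here, the one measured step, an at least 12-fold higher number from compound 1 to compound 2 (1.11 log units; beyond the scatter), shows that stripping an acyl group from an oxygen on a saturated carbon can cost much, with compound 2 sitting at the limit of > 100000 nM in this assay, at which 1 of the 3 values shown sits. Compound 4 `C/C=C(\C)C(=O)O[C@@H]1[C@]2(OC(=O)CCCC)C=C3C4=CC(=O)O[C@@H](c5ccoc5)[C@]4(C)CC[C@@H]3[C@@]3(C)[C@H](C[C@]1(C)[C@H]3[C@@H](O)C(=O)OC)O2` differs from compound 3 by hydrogen in place of butylcarbonyl on an oxygen on a saturated carbon. Since that step removes a different acyl group, a smaller weakening is expected, a 1.9-fold higher number from compound 3 to compound 4 (0.28 log units; within the scatter), so compound 4 is estimated at 8000 nM, between 3000 nM and 25000 nM.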

Compound 4, half-maximal inhibitory concentration: 5200 nM
The estimate for compound 4 lay 1.5-fold (0.19 log units) above the measured number; low and high end bracket the measured number.
By their numbers in this assay, from the lowest: compounds 3, 4 and 1 (each within the scatter of the next). At a limit, above all of these: compound 2.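

Taking butylcarbonyl off this oxygen on a saturated carbon gives a 1.2-fold higher number from compound 3 to compound 4 (0.09 log units; within the scatter), so this acyl group can go without the large loss seen when (1-methylprop-1-en-1-yl)carbonyl was removed. Butylcarbonyl in place of hydrogen on another oxygen likewise gives a 1.5-fold lower number from compound 1 to compound 4 (0.17 log units; within the scatter). Nothing measured here accounts for this difference between the two acyl groups.

Open, as far as these compounds go, is whether a longer chain or an amine on this oxygen would keep the number in the same range. Also open, from the compounds shown here alone, is whether removing (1-methylprop-1-en-1-yl)carbonyl from compound 4 would cost as much as it did from compound 1.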